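The compounds below may be only part of what the source reports. "The series", "measured", "known", "first", "only" and "open" are said of these compounds alone.

Compound 2 `Fc1ccc(-c2noc(C3CCc4c(nnn4-c4ccc(F)cc4)C3)n2)cc1` gives 15.9 nM in a functional assay on U2OS cells for positive allosteric modulation of metabotropic glutamate receptor 5 (Homo sapiens), read by calcium flux, in the presence of a further agent that is not named here (on this read-out lower numbers stand for an effect already at smaller amounts and higher numbers for an effect only at larger amounts of compound), the lowest of the three numbers measured. Compound 1 `Fc1ccc(-c2nc(-c3ccc4c(c3)nnn4C3CCCC3)no2)cc1` gives 398 nM, and compound 3 `CN1CCC(n2nnc3c2CCC(c2nc(-c4ccc(F)cc4)no2)C3)CC1` gives 3980 nM. Compound 4 `Fc1ccc(-c2noc(C3CCc4c(nnn4C4CCOC4)C3)n2)cc1` differs from compound 2 in one place: oxolan-3-yl in place of 4-fluorophenyl on an aromatic nitrogen. Within the data shown here, one measured step bears on this change, the exchange of the same 4-fluorophenyl on the aromatic nitrogen for a non-aromatic ring, which gave a 250-fold higher number from compound 2 to compound 3 (2.40 log units; beyond the scatter). Oxolan-3-yl is likewise a non-aromatic ring, so a clear loss is expected for compound 4, though one judged smaller than that step, estimated as a 25-fold higher number from compound 2 to compound 4 (1.40 log units; beyond the scatter). Compound 4 is therefore expected to give about 400 nM in this assay, within a range of 60 nM to 3000 nM.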

Compound 4, half-maximal effective concentration: 398 nM
Estimate against measurement, compound 4: 1.0-fold (0.00 log units) above; low and high end bracket the measured number.
By their numbers in this assay, from the lowest: compound 2; then compounds 1 and 4 (each within the scatter of the next); then compound 3.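

In this assay, a second non-aromatic ring on the aromatic nitrogen also falls behind 4-fluorophenyl (a 25-fold higher number from compound 2 to compound 4 (1.40 log units; beyond the scatter)), so the loss is not confined to 1-methylpiperidin-4-yl. Non-aromatic rings at this position are not interchangeable either, as oxolan-3-yl in place of 1-methylpiperidin-4-yl gives a clear difference (a 10-fold lower number from compound 3 to compound 4 (1.00 log units; beyond the scatter)). Nothing available explains either step. The compounds shown leave open whether an aromatic ring other than 4-fluorophenyl, such as pyridin-3-yl, would match compound 2, and whether an open chain such as 2-methoxyethyl would behave like oxolan-3-yl.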